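A few compounds are considered here, and "the series" means these few. Any claim that something is new, unique, unknown or untested is made for them only; others in the source may bear on it.

Notes on the series. Two compounds carry numbers in a functional assay on MDA-MB-435 cells (Homo sapiens) for inhibition, read by sulforhodamine B assay, with a stated time of 48 h; on this read-out lower numbers stand for stronger inhibition of growth and higher numbers for weaker inhibition of growth. Compound 1 `COc1ccc(-c2[nH]c3ccccc3c2/C=C(\C#N)S(=O)(=O)c2ccccc2)cc1` gives 203 nM in this assay, the lowest of the two numbers. Among the compounds with values here, compound 2 `CCOC(=O)C(=Cc1c(-c2ccccc2)[nH]c2ccccc12)C(=O)OCC` gives 3400 nM in this assay; the two structures differ in more than one place, so no single step links them and only the two values are noted, and the gap between them lies beyond the scatter. Compound 3 `COc1ccc(-c2[nH]c3ccc(OC)cc3c2/C=C(\C#N)S(=O)(=O)c2ccccc2)cc1` has not yet been measured in this assay. It differs from compound 1 by methoxy in place of hydrogen on an aromatic carbon, a methoxy in place of hydrogen on an aromatic carbon. Within the data shown here, no pair of measured compounds shows this change, so its size in this assay is not known from the data; a shift of modest size is expected, more likely toward a lower number than a higher one, though a result within the scatter of compound 1 is also possible. For compound 3 the estimate in this assay is 150 nM, within 40 nM to 600 nM. The expected step of a 1.4-fold lower number from compound 1 to compound 3 (0.13 log units; within the scatter) is estimated to be modest.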

Compound 3, concentration for 50% growth inhibition: 276 nM
The estimate for compound 3 lay 1.8-fold (0.26 log units) below the measured number; the range from low to high includes it.
By their numbers in this assay, from the lowest: compounds 1 and 3 (each within the scatter of the next); then compound 2.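

Within the data shown here, this is the first single-place step: methoxy in place of hydrogen on an aromatic carbon of the six-membered aromatic ring of carbon only, at the place meta to a fused ring and para to a fused ring, gives a 1.4-fold higher number from compound 1 to compound 3 (0.13 log units; within the scatter) in this assay on growth of these cells. The step therefore shows that this position of the core of compound 1 can carry a methoxy without a change that can be told apart from the usual scatter of the read-out, so this single change neither gains nor loses measurable growth inhibition. Nothing at hand bears on why the step is this small, and the result is recorded as an observation from one pair only.

Going by these compounds, whether this position would stay as undemanding with an amine, a carboxylic acid or a longer chain such as butoxy in place of the methoxy remains open. Also open, on these data alone, is whether a methoxy on other aromatic carbons of the shared core, or on the core of compound 2, would give a step of similar size.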